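A few compounds are considered here, and "the series" means these few. Any claim that something is new, unique, unknown or untested is made for them only; others in the source may bear on it.

Three compounds have been measured in an ADME assay on cells (Hepatocyte, Mus musculus) for cytotoxicity, read by MTT assay, with a stated time of 24 h; on this read-out lower numbers stand for higher toxicity in this test and higher numbers for lower toxicity in this test:

Compound 1 `Cc1ccc(-c2nn(-c3ccccc3)cc2-c2nc3ccccc3n2S(=O)(=O)c2ccc(Cl)cc2)cc1` gives 216000 nM.
Compound 2 `Cc1ccc(-c2nn(-c3ccccc3)cc2-c2nc3ccccc3n2S(=O)(=O)c2ccc(Br)cc2)cc1` reaches only the limit of the assay, > 300000 nM.
Compound 3 `O=S(=O)(c1ccc(Cl)cc1)n1c(-c2cn(-c3ccccc3)nc2-c2ccc(F)cc2)nc2ccccc21` gives 231000 nM.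

The change from compound 1 to compound 2 is bromo in place of chloro on an aromatic carbon. It brought an at least 1.3-fold higher number from compound 1 to compound 2 (0.14 log units; that floor lies within the scatter), and the value of compound 2 is a limit rather than a number (the limit of > 300000 nM in this assay, at which 1 of the 3 values shown sits). Compound 3 differs from compound 1 by fluoro in place of methyl on an aromatic carbon, and this gave a 1.1-fold higher number from compound 1 to compound 3 (0.03 log units; within the scatter).

Compound 4 `O=S(=O)(c1ccc(Br)cc1)n1c(-c2cn(-c3ccccc3)nc2-c2ccc(F)cc2)nc2ccccc21` has not yet been measured in this assay. It differs from compound 3 by bromo in place of chloro on an aromatic carbon, the same change as from compound 1 to compound 2, in the same place. From compound 3 to compound 4 a step of a 1.3-fold higher number from compound 3 to compound 4 (0.11 log units; within the scatter) is expected, resting on an at least 1.3-fold higher number from compound 1 to compound 2 (0.14 log units; that floor lies within the scatter), which is only a floor because compound 2 sits at the limit. For compound 4 the estimated value in this assay is 300000 nM, between 180000 nM and 500000 nM, with a real chance that the assay again reports only a limit.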

Compound 4, half-maximal cytotoxic concentration: > 300000 nM
Compound 4 was reported as a limit (the forecaster's own chance of this, stated with the estimate: 50%); the middle value sits exactly at the limit.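

Going from 4-chlorophenyl to 4-bromophenyl on the core of compound 3 gave an at least 1.2-fold higher number from compound 3 to compound 4 (0.11 log units; that floor lies within the scatter) in this assay. Set beside the same change on the core of compound 1, this shows no disagreement between the two cores, since the number does not fall on either one, but both figures are only floors that stay within the usual scatter, so neither a real gain nor its true size is shown, and neither is an equal effect on both cores: the same change on two cores in this assay, an at least 1.3-fold higher number (0.14 log units; that floor lies within the scatter) from compound 1 to compound 2 and an at least 1.2-fold higher number (0.11 log units; that floor lies within the scatter) from compound 3 to compound 4; the limit leaves it open whether they differ The step from compound 2 to compound 4, fluoro in place of methyl, cannot be read, as compound 2 and compound 4 are both reported only as a limit: the limit of > 300000 nM in this assay, at which 2 of the 4 values shown sit.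

The compounds shown leave open how far above that limit either bromo compound lies. They also leave open whether the number would hold with something other than a halogen at this place, such as an amine or a carboxylic acid.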